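The source may report more compounds than this note shows. Statements on the series, on what has been measured and on what is new or still open speak of the compounds shown alone.

Measured so far in a functional assay on cells (Homo sapiens) for antiproliferative activity, read by MTT assay, with a stated time of 48 h; a higher number here means a weaker inhibitor, a lower number a stronger inhibitor:
- Compound 1 `N#Cc1nc2c(-c3nc4ccccc4[nH]3)c(N)n(CCN3CCCC3)c2nc1C#N`: > 50000 nM (a limit)
- Compound 2 `CCCn1c(N)c(-c2nc3ccccc3[nH]2)c2nc(C#N)c(C#N)nc21`: > 50000 nM (a limit)

Compound 2 stands at > 50000 nM, which is a limit of the assay and not a number. Compound 1 stands at > 50000 nM, also a limit. The whole picture so far is therefore (the limit of > 50000 nM in this assay, at which 2 of the 2 values shown sit).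

Compound 3 `CN(C)CCCn1c(N)c(-c2nc3ccccc3[nH]2)c2nc(C#N)c(C#N)nc21` differs from compound 2 in one place: dimethylamino in place of hydrogen on a saturated chain carbon, three bonds along the chain from an aromatic nitrogen. The propyl chain becomes 3-(dimethylamino)propyl, with dimethylamino in place of hydrogen on a saturated chain carbon, three bonds along the chain from an aromatic nitrogen.

Going by the values given here, only one measured step bears on this change, and it also alters the chain: a step that the two limits leave unreadable from compound 1 to compound 2. It offers no size to carry over. Compound 1 carries pyrrolidin-1-yl on its chain and still gives > 50000 nM, so an amine on the chain of compound 3 gives no reason to expect a gain in this assay. The expected change, with no direction beyond the scatter, is a number no higher from compound 2 to compound 3 (the limit leaves the size open). Compound 3 is estimated at 50000 nM, with an expected range of 20000 nM to 100000 nM, and a result reported only as a limit is the likeliest outcome.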

Compound 3, half-maximal inhibitory concentration: 1820 nM
Estimate against measurement, compound 3: 27-fold (1.44 log units) above; the whole stated range lies above it.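

In this assay, going by these compounds alone, compound 3 gives the first value in this set that is a number and not a limit. Dimethylamino at the end of the propyl chain gives an at least 27-fold lower number from compound 2 to compound 3 (1.43 log units; beyond the scatter), so a single change on this saturated chain carbon, three bonds along the chain from an aromatic nitrogen, is enough to bring a readable effect on the cells. Compound 1 also carries an amine on its chain, yet an at least 27-fold lower number from compound 1 to compound 3 (1.43 log units; beyond the scatter) shows that an amine on the chain does not by itself bring the effect, although this step changes the amine and the chain length at once, and the step between compound 1 and compound 2 cannot be read: (the limit of > 50000 nM in this assay, at which 2 of the 3 values shown sit).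

As far as these compounds go, both large steps are measured against limits, so their true size stays unknown, and the step from compound 1 cannot separate the amine from the chain length. A pyrrolidin-1-yl group on the propyl chain, a dimethylamino group on an ethyl chain, or a longer chain ending in dimethylamino would tell which of the two matters, and a morpholine at the chain end would test how far the amine can vary.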